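Cyclohexyl for 4-methoxyphenyl: notes on compound 4

The source may report more compounds than this note shows. Statements on the series, on what has been measured and on what is new or still open speak of the compounds shown alone.

Values in an ADME assay on MT4 cells (Homo sapiens) for cytotoxicity, read by MTT assay, with a stated time of 96 h (on this read-out higher numbers stand for lower toxicity in this test and lower numbers for higher toxicity in this test), follow
- compound 1 `COc1ccc(-c2nc3cc(C(C)O)ccc3[nH]2)cc1` gives >= 100000 nM (a limit)
- compound 2 `COc1ccc(-c2nc3cc(/C(C)=N/NC(N)=S)ccc3[nH]2)cc1` gives 5000 nM
- compound 3 `COc1ccc(-c2nc3cc(/C(C)=N/NC(N)=S)ccc3n2C2CCCCC2)cc1` gives 39000 nM

Compound 2 holds the lower of the two actual numbers (5000 nM). Compound 4 `C/C(=N\NC(N)=S)c1ccc2[nH]c(C3CCCCC3)nc2c1` carries cyclohexyl in place of 4-methoxyphenyl on an aromatic carbon. For the measured compounds named here, two measured steps bear on this. The large one (an at least 20-fold lower number from compound 1 to compound 2 (1.30 log units; beyond the scatter)) concerns a group that compound 4 keeps. The modest one (a 7.8-fold higher number from compound 2 to compound 3 (0.89 log units; beyond the scatter)) also brings in cyclohexyl, but on an aromatic nitrogen, so it is only a loose guide. A small to modest rise is therefore expected (a 1.8-fold higher number from compound 2 to compound 4 (0.26 log units; within the scatter)). Compound 4 is estimated at 9000 nM (expected range 3000 nM to 30000 nM).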

Compound 4, half-maximal cytotoxic concentration: 48000 nM
Compound 4: the middle estimate sits 5.3-fold (0.73 log units) below what was measured; the measured number lies above the stated range.
By their numbers in this assay, from the lowest: compound 2; then compounds 3 and 4 (each within the scatter of the next). At a limit, above all of these: compound 1.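

In this assay, cyclohexyl in place of 4-methoxyphenyl on the aromatic carbon between two ring nitrogen atoms gives a 9.6-fold higher number from compound 2 to compound 4 (0.98 log units; beyond the scatter) and so the group held there does shift the read-out. For the compounds shown here, the earlier compounds all carry 4-methoxyphenyl at this place, so this is the first reading of it. Nothing in the evidence at hand bears on the cause of this step.

Still open, as far as these compounds go, is whether the change follows the methoxy group or the aromatic ring itself. An unsubstituted phenyl or a piperidine at this place would help to tell these apart.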